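A few compounds are considered here, and "the series" means these few. Any claim that something is new, unique, unknown or untested is made for them only; others in the source may bear on it.

In a functional assay on HepG2 cells (Homo sapiens) for antiproliferative activity, read by sulforhodamine B assay, with a stated time of 72 h (on this read-out lower numbers stand for stronger inhibition and higher numbers for weaker inhibition), compound 1 `C[C@@H](NC(=O)OC(C)(C)C)C(=O)Nc1ccc2ncnc(Nc3cccc(C(F)(F)F)c3)c2c1` is recorded only as a limit, > 50000 nM. For the measured compounds named here, compound 2 `CC(C)[C@@H](NC(=O)OC(C)(C)C)C(=O)Nc1ccc2ncnc(Nc3cccc(C(F)(F)F)c3)c2c1` gives 4300 nM, the only true number so far. Compound 3 `CC(C)C[C@@H](NC(=O)OC(C)(C)C)C(=O)Nc1ccc2ncnc(Nc3cccc(C(F)(F)F)c3)c2c1` carries isobutyl in place of isopropyl on a saturated chain carbon bound to an amide-type nitrogen and a carbonyl carbon. Going by the values given here, the one measured step at this carbon, isopropyl in place of methyl, is large: an at least 11-fold lower number from compound 1 to compound 2 (1.06 log units; beyond the scatter). A further chain change of this kind is expected to go the same way but by much less, and the estimated step is a 1.7-fold lower number from compound 2 to compound 3 (0.24 log units; within the scatter). For compound 3 the expected value is 2500 nM, with an estimated range of 700 nM to 9000 nM.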

Compound 3, half-maximal inhibitory concentration: > 50000 nM
Compound 3 gave a limit, no number; the forecaster's own chance of this, stated with the estimate: 8%; middle value at least 20-fold (1.30 log units) from the limit.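

Isobutyl at this carbon does not continue the gain seen with isopropyl but reverses it, with an at least 11-fold higher number from compound 2 to compound 3 (1.06 log units; beyond the scatter). Among the three compounds, only compound 2, with isopropyl, gives a true number, so the response does not follow chain size in one direction from methyl through isobutyl. The step between compound 1 and compound 3 cannot be read, as both are recorded only as limits: the limit of > 50000 nM in this assay, at which 2 of the 3 values shown sit.

Still open, from the compounds shown here alone, is whether a cyclopropyl or tert-butyl group at this carbon would match or improve on compound 2. Going by these compounds, it is also open how an amine or a carboxylic acid there would behave.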